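This account rests on a few compounds, and the source may have more. Where it says the series, first, only, none or still open, it means among the compounds named here.

Measured compounds: compound 1 `Cn1ccc2c(Oc3ccc(NC(=O)c4cc5cccnc5n(-c5ccc(Cl)cc5)c4=O)cc3)ccnc21` with 730 nM; compound 2 `Cn1ccc2c(Oc3ccc(NC(=O)c4cc5cccnc5n(-c5ccc(Br)cc5F)c4=O)cc3)ccnc21` with 2580 nM.

Within the data shown here, in a functional assay on HT-29 cells (Homo sapiens) for antiproliferative activity, read by MTT assay, with a stated time of 72 h (on this read-out lower numbers stand for stronger inhibition and higher numbers for weaker inhibition), compound 1 gives the lower of the two numbers measured so far. Among the measured compounds shown here, the only measured step, a 3.5-fold higher number from compound 1 to compound 2 (0.55 log units; beyond the scatter), changes the aryl group on the ring nitrogen and so touches a different part of the molecule.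

Compound 3 `Cn1ccc2c(Oc3ccc(NC(=O)c4cc5cccnc5n(-c5ccc(Cl)cc5)c4=O)cc3F)ccnc21` differs from compound 1 by fluoro in place of hydrogen on an aromatic carbon. For the measured compounds named here, no measured step changes this position, so the step from compound 1 to compound 2 bears only loosely on it: it shows that a halogen change elsewhere can move this read-out by a modest amount, but it gives no direction for the fluoro added here. The expectation is therefore a step of about a 1.0-fold lower number from compound 1 to compound 3 (0.02 log units; within the scatter), that is, nothing clearly beyond the scatter. For compound 3 the estimated value in this assay is 700 nM, within a range from 250 nM to 2000 nM.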

Compound 3, half-maximal inhibitory concentration: 220 nM
Compound 3: the middle estimate sits 3.2-fold (0.50 log units) above what was measured; measured number below the stated range.
By their numbers in this assay, from the lowest: compound 3; then compound 1; then compound 2.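

This position is not silent: in this assay, fluoro in place of hydrogen on an aromatic carbon, ortho to a large group and meta to a large group, gives a 3.3-fold lower number from compound 1 to compound 3 (0.52 log units; beyond the scatter). Among these compounds, a single added heavy atom on this ring is therefore enough to shift the read-out towards stronger inhibition, whereas the only earlier step, a 3.5-fold higher number from compound 1 to compound 2 (0.55 log units; beyond the scatter), went towards weaker inhibition and lay elsewhere in the molecule. Nothing given here explains why this fluoro has this effect.

The compounds shown compare only hydrogen and fluoro at this carbon, so it remains open whether a chloro group, a methoxy group or an amine there would shift the number the same way. On these data alone, it is also open whether fluoro would give a similar step alongside the 4-bromo-2-fluorophenyl group of compound 2.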